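Fluoro in place of hydroxy on the shared core

The source may report more compounds than this note shows. Statements on the series, on what has been measured and on what is new or still open speak of the compounds shown alone.

In a functional assay on KB cells (Homo sapiens) for cytotoxicity (on this read-out lower numbers stand for an effect already at smaller amounts and higher numbers for an effect only at larger amounts of compound), compound 1 (`Oc1cc(-c2ccccc2)nc2ccc(Cl)cc12`) gives 0.49 ug/mL and compound 2 (`Oc1ccc2c(O)cc(-c3ccccc3)nc2c1`) gives 0.55 ug/mL, two numbers within the scatter of each other. Among the measured compounds shown here, compound 2 therefore stands level with compound 1, and no measured pair yet differs in one place alone. Compound 3 (`Oc1cc(-c2ccccc2)nc2cc(F)ccc12`) carries fluoro in place of hydroxy on an aromatic carbon, on a six-membered aromatic ring of carbon only. For the measured compounds named here, no measured step shows what this change does, so the expectation rests on the two measured compounds alone: compound 1 at 0.49 ug/mL and compound 2 at 0.55 ug/mL lie together. No step beyond the scatter is expected, in either direction. The expected step is small (a 1.1-fold higher number from compound 2 to compound 3 (0.04 log units; within the scatter)). For compound 3 the estimate in this assay is 0.6 ug/mL, with an expected range from 0.2 ug/mL to 2 ug/mL.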

Compound 3, half-maximal effective concentration: < 0.1 ug/mL
Compound 3: a limit, no number; the forecaster's own chance of this, stated with the estimate: 8%; at least 6.0-fold (0.77 log units) between middle value and limit.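

In this assay, among the compounds shown here, fluoro in place of hydroxy on an aromatic carbon, meta to a fused ring and para to a fused ring, is the first single change that can be read, and it gives an at least 5.5-fold lower number from compound 2 to compound 3 (0.74 log units; beyond the scatter). This position is therefore not indifferent to the group it carries, which compounds 1 and 2 alone could not show. Compound 3 gives < 0.1 ug/mL, a limit and not a number, so the step fixes only a minimum size: the limit of < 0.1 ug/mL in this assay, at which 1 of the 3 values shown sits.

On these data alone, one pair cannot separate the loss of hydroxy from the arrival of fluoro, and the full size of the step stays open. Also open, as far as these compounds go, is how this position reads with a bare hydrogen, a methoxy group or an amine in the same place.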